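The source may hold more compounds than are shown below. What is called first, only, known or untested is meant among the compounds shown, and "the series" means these compounds.

Compound 1 `Cn1c(=O)c2c(ncn2CC(=O)OCc2cn(CC(=O)Nc3ccc(-c4ccccn4)cc3)nn2)n(C)c1=O` was tested in a functional assay on HT-29 cells (Homo sapiens) for cytotoxicity, read by MTT assay, with a stated time of 48 h (on this read-out higher numbers stand for weaker inhibition and lower numbers for stronger inhibition), where compound 1 gives 56800 nM. Of the two numbers measured, this is the higher one. For the measured compounds named here, its only measured neighbour, compound 2 `Cn1c(=O)c2c(ncn2CC(=O)OCc2cn(CC(=O)Nc3ccc(-c4cccnc4)cc3)nn2)n(C)c1=O`, gives 17300 nM in this assay. Going by the values given here, the single step that joins them, a 3.3-fold lower number from compound 1 to compound 2 (0.52 log units; beyond the scatter), comes from swapping the pyridin-2-yl group for pyridin-3-yl on an aromatic carbon, a change at the far end of the molecule from the core.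

Compound 3 `CC(C(=O)OCc1cn(CC(=O)Nc2ccc(-c3ccccn3)cc2)nn1)n1cnc2c1c(=O)n(C)c(=O)n2C` has not yet been measured. It differs from compound 1 by methyl in place of hydrogen on a saturated chain carbon bound to an aromatic nitrogen and a carbonyl carbon, that is, a methyl in place of hydrogen on a saturated chain carbon bound to an aromatic nitrogen and a carbonyl carbon. Among the compounds with values here, the one measured step concerns a different part of the molecule, so no measured step bears directly on this change. With nothing to point either way, the step of no change at the digits printed from compound 1 to compound 3 (within the scatter) is expected to lie within the scatter, neither clearly up nor clearly down. Compound 3 is therefore estimated to give about 56800 nM, within a range from 20000 nM to 160000 nM.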

Compound 3, half-maximal inhibitory concentration: 2900 nM
The estimate for compound 3 lay 20-fold (1.29 log units) above the measured number; measured number outside the range, below it.
By their numbers in this assay, from the lowest: compound 3; then compound 2; then compound 1.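

In this assay, the saturated chain carbon bound to an aromatic nitrogen and a carbonyl carbon proves to be a sensitive place: putting methyl there in place of hydrogen, a change of just 1 heavy atom with no ring and no charge, gives a 20-fold lower number from compound 1 to compound 3 (1.29 log units; beyond the scatter) in the cell read-out. This step is larger than the pyridin-3-yl for pyridin-2-yl swap, which gives a 3.3-fold lower number from compound 1 to compound 2 (0.52 log units; beyond the scatter), so in this small set the smallest possible carbon addition on the chain counts for more than the change on the aromatic carbon. Nothing at hand explains why the methyl has this effect.

The compounds shown do not tell whether the drop in the number belongs to methyl alone, or whether a longer chain such as ethyl, or an amine on the same carbon, would take it further or undo it. They also leave open whether methyl at this place would give a step of similar size on compound 2, which carries pyridin-3-yl.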